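The compounds below may be only part of what the source reports. "The series", "measured", "known", "first", "only" and "open" are said of these compounds alone.

Compound 3 `O=c1ccoc2cc(OCc3cn(Cc4ccc(F)cc4)nn3)ccc12` bears a 4-fluorophenyl group on a saturated chain carbon bound to an aromatic nitrogen. In a functional assay on MDA-MB-231 cells (Homo sapiens) for cytotoxicity, read by MTT assay, with a stated time of 48 h (a higher number here means a weaker inhibitor, a lower number a stronger inhibitor), compound 3 gives only a limit of the assay, > 100000 nM. Compound 1 `Cc1ccc(Cn2cc(COc3ccc4c(=O)ccoc4c3)nn2)cc1` carries a methyl on an aromatic carbon in place of that fluoro; in this assay compound 1 also gives only a limit, > 100000 nM. Compound 2 `O=c1ccoc2cc(OCc3cn(Cc4ccc(Cl)cc4)nn3)ccc12` carries a chloro instead; in this assay compound 2 likewise gives only a limit, > 100000 nM. All three values therefore sit together, as noted in the limit of > 100000 nM in this assay, at which 3 of the 3 values shown sit, and the steps a step that the two limits leave unreadable from compound 1 to compound 2, a step that the two limits leave unreadable from compound 1 to compound 3 and a step that the two limits leave unreadable from compound 2 to compound 3 cannot be read in size or direction. Compound 4 `O=c1ccoc2cc(OCc3cn(Cc4cccc([N+](=O)[O-])c4)nn3)ccc12` differs from compound 3 in that (3-nitrophenyl in place of 4-fluorophenyl on a saturated chain carbon bound to an aromatic nitrogen). Among the measured compounds shown here, no measured step bears directly on a nitro group here, and every step among the measured compounds is unreadable, so nothing points to a change beyond the scatter. Compound 4 is expected to show the step that the limit leaves unreadable from compound 3 to compound 4. Compound 4 is thus estimated at 120000 nM, within a range of 30000 nM to 400000 nM, most probably again only a limit.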

Compound 4, half-maximal inhibitory concentration: > 100000 nM
Compound 4: no number, only a limit (the forecaster's own chance of this, stated with the estimate: 70%); the middle value lies beyond the limit too.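

In this assay compound 4 gives > 100000 nM and this is only a limit, so its steps from compound 1, compound 2 and compound 3 cannot be read. The compounds shown leave open whether any group at this place on the shared core gives a measurable value, as all sit together: the limit of > 100000 nM in this assay, at which 4 of the 4 values shown sit.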